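The source may report more compounds than this note shows. Statements on the series, on what has been measured and on what is new or still open speak of the compounds shown alone.

Measured so far:
- compound 1, `CN(c1cccc2c1CN(c1nc(Nc3ccc(Cl)c(C(F)(F)F)c3)ncc1C(F)(F)F)C2)S(C)(=O)=O`: 11100 nM
- compound 2, `COc1cc(N2CCN(C(C)=O)CC2)ccc1Nc1ncc(C(F)(F)F)c(N2Cc3cccc(N(C)S(C)(=O)=O)c3C2)n1`: 1300 nM

In a functional assay on HeLa cells (Homo sapiens) for antiproliferative activity, read by spectrophotometry, with a stated time of 2 days (on this read-out higher numbers stand for weaker inhibition of growth and lower numbers for stronger inhibition of growth), compound 1 gives 11100 nM, the highest of the two numbers recorded. Compound 2, in this assay , gives 1300 nM, a lower number, and the gap between the two lies beyond the usual scatter. Compound 2 differs from compound 1 at more than one place, so its number says nothing about any single change.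

The unmeasured compound 3, `CN(c1cccc2c1CN(c1nc(Nc3cc(Cl)cc(C(F)(F)F)c3)ncc1C(F)(F)F)C2)S(C)(=O)=O`, differs from compound 1 in one place: 3-chloro-5-(trifluoromethyl)phenyl in place of 4-chloro-3-(trifluoromethyl)phenyl on a nitrogen on an aromatic ring. The same atoms are present, joined differently; the chlorine and the trifluoromethyl sit at other positions of the ring. Among the measured compounds shown here, no step of this kind has been measured, so there is no comparison to lean on. The expected step in this assay , a 1.1-fold lower number from compound 1 to compound 3 (0.05 log units; within the scatter), is taken as none beyond the scatter, in either direction. Compound 3 is therefore estimated at 10000 nM, with a range from 3500 nM to 30000 nM.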

Compound 3, concentration for 50% growth inhibition: 4300 nM
Compound 3: the middle estimate sits 2.3-fold (0.37 log units) above what was measured, within the range that was stated.
By their numbers in this assay, from the lowest: compound 2; then compound 3; then compound 1.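

Among the compounds shown here, this is the first single-place comparison: in this assay, 3-chloro-5-(trifluoromethyl)phenyl in place of 4-chloro-3-(trifluoromethyl)phenyl on a nitrogen on an aromatic ring gives a 2.6-fold lower number from compound 1 to compound 3 (0.41 log units; beyond the scatter), a modest step. The two groups have the same atoms, so the arrangement of the chlorine and the trifluoromethyl on this ring is enough on its own to move the number beyond the scatter. Nothing available bears on why the number moves.

Open, going by these compounds, is how far this position tolerates other groups: a phenyl ring with a nitrile in place of the chlorine, or with a morpholine in place of the trifluoromethyl, would test whether the step depends on these two groups. Also open, on these data alone, is whether the same rearrangement gives a similar step on other versions of the shared core.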